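Replacing a styryl arm with a dimethoxyphenyl ring

The source may hold more compounds than are shown below. What is called first, only, known or untested is meant among the compounds shown, and "the series" means these compounds.

Compound 2 `Cc1cc(O)c(C2=NN(c3ccc(S(N)(=O)=O)cc3)C(/C=C/c3ccccc3)C2)cc1Cl` carries a 2-phenylethenyl group on a saturated ring carbon of the shared core. Within the data shown here, in a functional assay on NCI/ADR-RES cells (Homo sapiens) for antiproliferative activity, with a stated time of 48 h (a higher number here means a weaker inhibitor of growth, a lower number a stronger inhibitor of growth), compound 2 gives 9260 nM, the highest of the two numbers measured so far. Among the measured compounds shown here, its only measured neighbour is compound 1 `Cc1cc(O)c(C2=NN(c3ccc(S(N)(=O)=O)cc3)C(c3ccccc3O)C2)cc1Cl`, which bears a 2-hydroxyphenyl group on that saturated ring carbon; in this assay compound 1 gives 3610 nM. For the measured compounds named here, the one step measured, a 2.6-fold higher number from compound 1 to compound 2 (0.41 log units; beyond the scatter), shows that trading an aromatic ring for the 2-phenylethenyl chain weakened growth inhibition. Compound 3 `COc1ccc(C2CC(c3cc(Cl)c(C)cc3O)=NN2c2ccc(S(N)(=O)=O)cc2)cc1OC` moves the other way: 3,4-dimethoxyphenyl in place of 2-phenylethenyl on a saturated ring carbon. Compound 3 is expected to bring the number back down by a modest step, a 2.1-fold lower number from compound 2 to compound 3 (0.31 log units; beyond the scatter), because a 2.6-fold higher number from compound 1 to compound 2 (0.41 log units; beyond the scatter) went in the weaker direction when the aromatic ring was lost. Compound 3 is therefore estimated at 4500 nM in this assay, within a range of 2000 nM to 12000 nM.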

Compound 3, concentration for 50% growth inhibition: 3390 nM
Compound 3: middle estimate off by 1.3-fold (0.12 log units), on the high side, within the range that was stated.
By their numbers in this assay, from the lowest: compounds 3 and 1 (each within the scatter of the next); then compound 2.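

In this assay, a second ring on this saturated ring carbon gives a 2.7-fold lower number from compound 2 to compound 3 (0.44 log units; beyond the scatter), so the higher number of compound 2 is not reversed by the 2-hydroxyphenyl group alone. The change between the two rings gives a 1.1-fold lower number from compound 1 to compound 3 (0.03 log units; within the scatter), which means that 2-hydroxyphenyl and 3,4-dimethoxyphenyl cannot be told apart here, and among these three compounds only the 2-phenylethenyl chain of compound 2 stands apart. Nothing shown here explains the difference between the chain and the rings.

Still open, as far as these compounds go, is whether an unsubstituted phenyl ring would give a number like those of compound 1 and compound 3 or like that of compound 2. Also open, from the compounds shown here alone, is how this position would respond to a saturated propyl chain, or to a phenyl ring carrying an amine or a carboxylic acid.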